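This account rests on a few compounds, and the source may have more. Where it says the series, first, only, none or still open, it means among the compounds named here.

Measured so far in a functional assay on MDA-MB-231 cells (Homo sapiens) for antiproliferative activity, read by MTT assay, with a stated time of 72 h; a higher number here means a weaker inhibitor, a lower number a stronger inhibitor

Compound 1 `CC(=O)Oc1ccccc1C(=O)NCC[Se]C#N` gives 6000 nM
Compound 2 `CC(=O)Oc1ccccc1C(=O)OCC[Se]C#N` gives 34300 nM
Compound 3 `C[Se]CC(NC(=O)c1ccccc1OC(C)=O)C(=O)O` gives > 50000 nM (a limit of the assay, not a number)

Of the two results that are true numbers, compound 1 has the lower one, which makes it the stronger inhibitor of that pair. Compound 4 `CC(=O)Oc1ccccc1C(=O)NCCSC#N` keeps the core of compound 1 and alters one thing: a group of 3 heavy atoms (1 carbon, 1 nitrogen, 1 sulfur; no ring) in place of a group of 3 heavy atoms (1 carbon, 1 nitrogen, 1 selenium; no ring), on a saturated chain carbon, two bonds along the chain from an amide-type nitrogen. In plain terms, the selenium-bearing end of the chain gives way to cyanosulfanyl.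

Going by the values given here, no measured step makes this exchange. Among the compounds with values here, the only step available is a 5.7-fold higher number from compound 1 to compound 2 (0.76 log units; beyond the scatter), a modest change beyond the scatter. It alters the group on a carbonyl carbon and keeps the selenium, so it offers a yardstick for size and says nothing direct about sulfur in place of selenium.

Compound 1 already sits at the low end with 6000 nM, so a change to it is expected to raise the number in this assay rather than lower it. The expected size is similar to that yardstick, and a result within the scatter remains possible. The estimated change is a 2.7-fold higher number from compound 1 to compound 4 (0.43 log units; beyond the scatter), with a weaker result expected. For compound 4 the expected value is 16000 nM, with an estimated range from 6000 nM to 45000 nM.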

Compound 4, half-maximal inhibitory concentration: > 50000 nM
Compound 4 gave a limit, no number; the forecaster's own chance of this, stated with the estimate: 15%; middle value at least 3.1-fold (0.49 log units) from the limit.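

In this assay compound 4 gives > 50000 nM, a limit of the assay and not a number. Going by these compounds alone, this is the first direct look at sulfur in place of selenium on this chain with the amide kept, and the exchange gives an at least 8.3-fold higher number from compound 1 to compound 4 (0.92 log units; beyond the scatter), so even the floor of this step lies beyond the scatter and the selenium-bearing end matters for the result in this pair. As far as these compounds go, the other new step, an at least 1.4-fold higher number from compound 2 to compound 4 (0.16 log units; that floor lies within the scatter), does not separate compound 4 from compound 2 beyond the scatter, and the full size of both steps stays unknown because the reading stops at a limit: the limit of > 50000 nM in this assay, at which 2 of the 4 values shown sit.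

The compounds shown leave open how far above that limit compound 4 lies, so the real size of the exchange from selenium to sulfur is still unknown. They also leave open whether a longer chain carrying the same selenium-bearing end, or an amine in place of that end, would hold, raise or lower the number seen for compound 1.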